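Adding a Second Methoxy Group to a Bis-Benzylidene Cyclohexanone

This account rests on a few compounds, and the source may have more. Where it says the series, first, only, none or still open, it means among the compounds named here.

Compound 1 `COc1cccc(/C=C2\CCC/C(=C\c3ccc(OC)c(OC)c3)C2=O)c1` was tested in a functional assay on MCF7 cells (Homo sapiens) for cytotoxicity, read by MTT assay, with a stated time of 72 h (a higher number here means a weaker inhibitor, a lower number a stronger inhibitor), where compound 1 gives 4600 nM. Compound 2 `COc1ccc(/C=C2\CCC/C(=C\c3ccc(OC)c(OC)c3)C2=O)cc1` differs from it in the core, the difference being (3-methoxyphenyl in place of 4-methoxyphenyl on a double-bonded chain carbon bound to a double-bonded ring carbon), and in this assay compound 2 gives 7800 nM; the step is a 1.7-fold higher number from compound 1 to compound 2 (0.23 log units; within the scatter). Compound 3 `COc1ccc(/C=C2\CCC/C(=C\c3ccc(OC)c(OC)c3)C2=O)c(OC)c1` carries the change methoxy in place of hydrogen on an aromatic carbon and gives 15600 nM; that step is a 2.0-fold higher number from compound 2 to compound 3 (0.30 log units; within the scatter). Compound 4 `COc1cc(/C=C2\CCC/C(=C\c3ccc(OC)c(OC)c3)C2=O)cc(OC)c1` bears the same kind of change on the core of compound 1, namely (methoxy in place of hydrogen on an aromatic carbon), but here the new group sits meta to a large group, whereas in compound 3 it sits ortho to a large group. Resting on the step from compound 2 to compound 3, compound 4 is expected to show a 1.7-fold higher number from compound 1 to compound 4 (0.24 log units; within the scatter), giving an estimated 8000 nM, between 3000 nM and 20000 nM.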

Compound 4, half-maximal inhibitory concentration: 3900 nM
Compound 4: middle estimate off by 2.1-fold (0.31 log units), on the high side; the range from low to high includes it.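

In this assay, the added methoxy on the core of compound 1 gives a 1.2-fold lower number from compound 1 to compound 4 (0.07 log units; within the scatter). Set beside the earlier step, the same change on the two cores does not differ by more than repeated measurement allows: the same change on two cores in this assay, a 2.0-fold higher number (0.30 log units; within the scatter) from compound 2 to compound 3 and a 1.2-fold lower number (0.07 log units; within the scatter) from compound 1 to compound 4, 2.4-fold (0.37 log units) apart, within the scatter of two such steps. This gives no sign that the change behaves differently on the two cores, but it does not show that the change carries over unchanged, as two small steps, with the new group placed differently on each core, are too little to establish that.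

The compounds shown leave open how a hydroxy group or an amine in place of the methoxy would read in this assay. They also leave open whether any change on this ring would give a step beyond the scatter.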